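This account rests on a few compounds, and the source may have more. Where it says the series, first, only, none or still open, it means among the compounds named here.

The three measured compounds, all tested in an assay on isolated protein for displacement of a labelled ligand from metabotropic glutamate receptor 5 (Homo sapiens), with a stated time of 60 min, tested at 1 uM (a lower number here means less inhibition, a higher number more inhibition at the concentration tested (going by the name of the read-out)), are:

compound 1, `Cc1ccc(S(=O)(=O)c2cnc3c(F)cccc3c2N2CCC(C)CC2)cc1`, giving 93%
compound 2, `COc1ccc(S(=O)(=O)c2cnc3c(F)cccc3c2N2CCC(C)CC2)cc1`, giving 67%
compound 3, `CC1CCN(c2c(S(=O)(=O)c3ccccc3)cnc3c(F)cccc23)CC1`, giving 13%

Compound 3 stands lowest of the three in this assay, its nearest neighbour being compound 2 and the furthest compound 1. The unmeasured compound 4, `CC1CCN(c2c(S(=O)(=O)c3ccc(Cl)cc3)cnc3c(F)cccc23)CC1`, differs from compound 3 by chloro in place of hydrogen on an aromatic carbon, the chlorine entering on an aromatic carbon of a six-membered aromatic ring of carbon only, para to a large group.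

Among the measured compounds shown here, two measured steps bear on this change, both taking a group off that same carbon: a number 80 percentage points lower from compound 1 to compound 3 (beyond the scatter) and a number 54 percentage points lower from compound 2 to compound 3 (beyond the scatter). Both are large and both run downward when the substituent is removed, so putting a single heavy atom back at that carbon is expected to run upward by a large amount, though the scatter between methyl and methoxy shows the size depends on the group. Compound 4 is therefore estimated at 75% in this assay, with a range from 40% to 95%. That estimate corresponds to an expected step of a number 62 percentage points higher from compound 3 to compound 4 (beyond the scatter).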

Compound 4, a percentage reported as inhibition, at one concentration (the size of the read-out at that concentration, not a potency): 85%
Compound 4: middle estimate off by 10 percentage points, on the low side; low and high end bracket the measured number.
By their numbers in this assay, from the lowest: compound 3; then compound 2; then compounds 4 and 1 (each within the scatter of the next).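

In this assay chloro on this aromatic carbon gives a number 72 percentage points higher from compound 3 to compound 4 (beyond the scatter), which shows that a single chlorine atom can also carry the read-out well clear of the unsubstituted phenyl of compound 3. The two earlier substituents had shown this only for methyl and methoxy, and the comparison now separates chloro from methoxy, with a number 18 percentage points higher from compound 2 to compound 4 (beyond the scatter), but not from methyl, with a number 8 percentage points lower from compound 1 to compound 4 (within the scatter). No measurement is available to explain why a substituent at this carbon matters so much.

As far as these compounds go, whether bromo, a nitrile or an amine at this carbon would hold the read-out at the level of compound 4 remains open. From the compounds shown here alone, it is also open whether chloro would have the same effect on another carbon of this ring.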